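A few compounds are considered here, and "the series" means these few. Any claim that something is new, unique, unknown or untested is made for them only; others in the source may bear on it.

Series notes. Compound 1 `COc1ccccc1-n1nncc1CN1C(=O)C2(C(C#N)=C(N)Oc3c(N)cc4nc5ccccc5nc4c32)c2ccccc21` carries a 2-methoxyphenyl on the aromatic nitrogen; in a functional assay on A549 cells (Homo sapiens) for antiproliferative activity, read by MTT assay, with a stated time of 48 h (on this read-out higher numbers stand for weaker inhibition and lower numbers for stronger inhibition), compound 1 gives 37500 nM. Compound 2 `Cc1ccc(-n2nncc2CN2C(=O)C3(C(C#N)=C(N)Oc4c(N)cc5nc6ccccc6nc5c43)c3ccccc32)cc1C` carries a 3,4-dimethylphenyl in that place. In this assay compound 2 reaches only the limit of the assay, > 50000 nM, so no number is known for it. For the measured compounds named here, the one measured step, an at least 1.3-fold higher number from compound 1 to compound 2 (0.12 log units; that floor lies within the scatter), points toward weaker inhibition. That step ends at compound 2, whose result is a limit (the limit of > 50000 nM in this assay, at which 1 of the 2 values shown sits), and its floor stays within the scatter. Compound 3 `CCc1cccc(C)c1-n1nncc1CN1C(=O)C2(C(C#N)=C(N)Oc3c(N)cc4nc5ccccc5nc4c32)c2ccccc21` is the next member: 2-ethyl-6-methylphenyl in place of 3,4-dimethylphenyl on an aromatic nitrogen. Going by the values given here, no measured step covers an exchange between two alkyl-substituted phenyl groups; the only related change, from compound 1 to compound 2, gave no movement that clears the scatter. The step expected here, a step that the limit leaves unreadable from compound 2 to compound 3, is therefore none beyond the scatter, and this assay may again return only a limit. Compound 3 is estimated at 55000 nM, within a range from 25000 nM to 150000 nM.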

Compound 3, half-maximal inhibitory concentration: > 50000 nM
Compound 3 gave a limit, no number; the forecaster's own chance of this, stated with the estimate: 60%; the middle value does not contradict the limit.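

In this assay compound 3 also gives only a limit, > 50000 nM, and no number. With the 2-ethyl-6-methylphenyl on the aromatic nitrogen, a second alkyl-substituted phenyl group now ends at this limit, a result that compound 2 alone had shown until now: the limit of > 50000 nM in this assay, at which 2 of the 3 values shown sit. The one readable step is an at least 1.3-fold higher number from compound 1 to compound 3 (0.12 log units; that floor lies within the scatter), and the steps between the limits cannot be read, so the three phenyl groups shown are not separated by any measured difference.

On these data alone, how far compound 2 and compound 3 lie past the limit remains open. Also open, as far as these compounds go, is whether a phenyl group carrying an amine or a carboxylic acid, or a longer alkyl chain in place of the phenyl group, would give a number in this assay.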